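The compounds below may be only part of what the source reports. "The series", "measured", "known", "first", "only" and "open" are said of these compounds alone.

Working notes on the pyrazolyl dihydropyrimidine series.

Of the compounds shown here, three have a number so far. Compound 1 `CCOC(=O)C1=C(C)NC(=O)NC1c1cn(-c2ccccc2)nc1-c1ccccc1` gives 60800 nM in a functional assay on MCF7 cells (Homo sapiens) for inhibition, read by sulforhodamine B assay, with a stated time of 24 h; on this read-out higher numbers stand for weaker inhibition of growth and lower numbers for stronger inhibition of growth. Compound 3 `CC1=C(C(=O)Nc2ccc(C)cc2)C(c2cn(-c3ccccc3)nc2-c2ccccc2)NC(=O)N1` carries a (4-methylphenyl)amino group on the carbonyl carbon in place of the ethoxy group of compound 1; in this assay compound 3 gives 71700 nM, and the step of a 1.2-fold higher number from compound 1 to compound 3 (0.07 log units; within the scatter) is within the scatter. Compound 2 `CC1=C(C(=O)Nc2ccccc2)C(c2cn(-c3ccccc3)nc2-c2ccccc2)NC(=S)N1`, the thione with an unsubstituted anilide, gives 88200 nM in this assay; that number lies within the scatter of compound 3 and of compound 1, so compound 2 stands level with both on the numbers shown.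

Compound 4 `COc1ccc(NC(=O)C2=C(C)NC(=S)NC2c2cn(-c3ccccc3)nc2-c2ccccc2)cc1` is not yet measured. It differs from compound 2 by methoxy in place of hydrogen on an aromatic carbon. Going by the values given here, no measured step alters this ring in this way. Among the compounds with values here, the only measured step, from compound 1 to compound 3, changes a different part of the molecule and was within the scatter; compound 2 and compound 3, which differ in two places including the methyl on this ring, also sit within the scatter of each other. The step of a 1.1-fold lower number from compound 2 to compound 4 (0.04 log units; within the scatter) is therefore expected to stay within the scatter. Compound 4 is estimated at 80000 nM in this assay, with a range of 40000 nM to 160000 nM.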

Compound 4, concentration for 50% growth inhibition: 77300 nM
Compound 4: the middle estimate sits 1.0-fold (0.01 log units) above what was measured, and the stated range covers the measured number.
By their numbers in this assay, from the lowest: compounds 1, 3, 4 and 2 (each within the scatter of the next).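

In this assay, methoxy in place of hydrogen on the aromatic carbon para to a large group gives a 1.1-fold lower number from compound 2 to compound 4 (0.06 log units; within the scatter), so this substitution leaves the thione anilide level with its unsubstituted parent. Going by these compounds alone, this is the first reading of a change on this ring; the earlier step, a 1.2-fold higher number from compound 1 to compound 3 (0.07 log units; within the scatter), concerned the group on the carbonyl carbon and could not speak to this position. The reading covers a single group at a single place, and nothing measured here accounts for the absence of a shift beyond the scatter.

Whether any group at this place can move the number beyond the scatter stays open: an amine, a carboxylic acid or a longer alkoxy chain in place of methoxy would test that, and the compounds shown give no step for any of them. It also remains open whether methoxy on this ring reads the same when the thione is replaced by the carbonyl of compound 3, since no pair shown isolates that change.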